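A few compounds are considered here, and "the series" means these few. Any claim that something is new, unique, unknown or untested is made for them only; others in the source may bear on it.

Within the data shown here, compound 2 `Fc1ccc(C2(c3ccc(F)cc3)CNC(c3cccs3)=N2)cc1` gives 54 nM in an assay on LM cells for displacement of a labelled ligand from Neuropeptide Y receptor type 5 (Homo sapiens) (a higher number here means a weaker inhibitor, a lower number a stronger inhibitor), the higher of the two numbers measured so far; compound 1 `O=[N+]([O-])c1cccc(C2=NC(c3ccc(F)cc3)(c3ccc(F)cc3)CN2)c1` gives 4.3 nM. Among the measured compounds shown here, the single measured step, a 13-fold higher number from compound 1 to compound 2 (1.10 log units; beyond the scatter), shows that exchanging the aryl group on the carbon with a double bond to nitrogen can shift the number well beyond the scatter. Compound 3 `Fc1ccc(C2(c3ccc(F)cc3)CNC(c3ccccn3)=N2)cc1` carries pyridin-2-yl in place of thiophen-2-yl on a carbon with a double bond to nitrogen. For the measured compounds named here, no measured step matches this exact exchange, so only the size of that one step informs the guess. For compound 3 a modest step toward a lower number is expected, a 1.8-fold lower number from compound 2 to compound 3 (0.26 log units; within the scatter), estimated at 30 nM within 8 nM to 120 nM.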

Compound 3, half-maximal inhibitory concentration: 160 nM
Compound 3: middle estimate off by 5.3-fold (0.73 log units), on the low side, and the stated range ends below it.
By their numbers in this assay, from the lowest: compound 1; then compound 2; then compound 3.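

In this assay, the position on the carbon with a double bond to nitrogen also separates two single-ring groups with one hetero atom each: pyridin-2-yl in place of thiophen-2-yl gives a 3.0-fold higher number from compound 2 to compound 3 (0.47 log units; beyond the scatter). Against 3-nitrophenyl, pyridin-2-yl gives a 37-fold higher number from compound 1 to compound 3 (1.57 log units; beyond the scatter), the largest step in the series, so the order from lowest number is 3-nitrophenyl, thiophen-2-yl, pyridin-2-yl. Nothing available accounts for this order.

Open, as far as these compounds go, is whether the nitro group itself matters, or whether unsubstituted phenyl would match compound 1. Also open, from the compounds shown here alone, is how an amine or carboxylic acid at that ring position would compare.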